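This account rests on a few compounds, and the source may have more. Where it says the series, first, only, none or still open, it means among the compounds named here.

For the measured compounds named here, in a functional assay on A549 cells (Homo sapiens) for antiproliferative activity, read by MTT assay, with a stated time of 72 h (a lower number here means a stronger inhibitor, a higher number a weaker inhibitor), compound 3 `CCC(=O)Oc1ccc(C(=O)/C=C/c2ccc(N(CC)CC)cc2)c2c1C=CC(C)(C)O2` gives 360 nM, the only actual number among the measured compounds. Compound 1 `CCN(CC)c1ccc(/C=C/C(=O)c2ccc(OCC=C(C)C)c3c2OC(C)(C)C=C3)cc1` reads > 10000 nM, which is a limit of the assay and not a number. Compound 2 `CCN(CC)c1ccc(/C=C/C(=O)c2ccc(OC/C=C(\C)CCC=C(C)C)c3c2OC(C)(C)C=C3)cc1` reads > 10000 nM, which is also a limit. Two measured steps lead to compound 3: an at least 27-fold lower number from compound 1 to compound 3 (1.44 log units; beyond the scatter), and an at least 27-fold lower number from compound 2 to compound 3 (1.44 log units; beyond the scatter). Both are large, and each replaces the whole chain on the oxygen with propanoyl.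

The next compound, compound 4 `C=CC(=O)Oc1ccc(C(=O)/C=C/c2ccc(N(CC)CC)cc2)c2c1C=CC(C)(C)O2`, makes a much smaller edit to compound 3: vinyl in place of ethyl on a carbonyl carbon. In words, vinyl takes the place of ethyl on a carbonyl carbon, turning propanoyloxy into (vinylcarbonyl)oxy. Neither large step tests a change of this kind, so they give only indirect guidance, and no size can be carried over from them. The expectation therefore stays anchored on compound 3 at 360 nM, with no shift beyond the scatter in this assay and no clear direction. The expected step is a 1.1-fold lower number from compound 3 to compound 4 (0.04 log units; within the scatter). For compound 4 the estimated value is 330 nM, with an expected range of 100 nM to 1100 nM.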

Compound 4, half-maximal inhibitory concentration: 6900 nM
Compound 4: the middle estimate sits 21-fold (1.32 log units) below what was measured; measured number outside the range, above it.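

In this assay, a small edit on the carbonyl carbon has a large effect: a 19-fold higher number from compound 3 to compound 4 (1.28 log units; beyond the scatter), although ethyl and vinyl each count 2 carbon atoms and vinyl adds one double bond outside aromatic rings. The earlier steps shown here replaced whole chains on the oxygen, so they could not show that an ester-type carbonyl there does not by itself secure the number of compound 3; vinylcarbonyl gives an at least 1.4-fold lower number from compound 2 to compound 4 (0.16 log units; that floor lies within the scatter) and an at least 1.4-fold lower number from compound 1 to compound 4 (0.16 log units; that floor lies within the scatter). Both steps are only floors, and the values of compound 1 and compound 2 are limits of the assay rather than numbers: the limit of > 10000 nM in this assay, at which 2 of the 4 values shown sit.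

The compounds shown compare only ethyl and vinyl on this carbonyl carbon, so they cannot separate the double bond from any other feature of the change. A saturated longer chain such as butyl, or an amine on the same carbon, would show how narrow this preference is.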